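Swapping the Basic Tail on a Kinase-Type Amide Scaffold

The compounds below may be only part of what the source reports. "The series", "measured", "known", "first", "only" and "open" are said of these compounds alone.

Compound 1, with structure `COc1cc2c(Oc3ccc(NC(=O)c4cc(-c5ccccc5C)ccn4)cc3F)ccnc2cc1OCCCN1CCN(C)CC1`, gives 180 nM in a functional assay on HT-29 cells (Homo sapiens) for cytotoxicity, read by MTT assay, with a stated time of 72 h; a lower number here means a stronger inhibitor, a higher number a weaker inhibitor. Among the measured compounds shown here, compound 2, with structure `COc1cc2c(Oc3ccc(NC(=O)c4cc(-c5ccc(F)cc5)ccn4)cc3F)ccnc2cc1OCCCN1CCN(C)CC1`, gives 1460 nM in this assay, and the only measured step, an 8.1-fold higher number from compound 1 to compound 2 (0.91 log units; beyond the scatter), comes from replacing a 2-methylphenyl with a 4-fluorophenyl on an aromatic carbon. Compound 1 therefore stands as the lower of the two numbers shown, with compound 2 as its only neighbour.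

Compound 3, with structure `COc1cc2c(Oc3ccc(NC(=O)c4cc(-c5ccccc5C)ccn4)cc3F)ccnc2cc1OCCCN1CCCC1`, keeps everything in compound 1 except one change: pyrrolidin-1-yl in place of 4-methylpiperazin-1-yl on a saturated chain carbon, three bonds along the chain from an oxygen on an aromatic ring. The measured step from compound 1 to compound 2 altered a different part of the molecule, the aryl group on the amide side, so it offers no direct guide to a change in the amine-bearing tail. For the measured compounds named here, with no measured step touching this tail, the expectation for compound 3 is a step of small size, most likely none beyond the scatter, expressed as a 1.1-fold higher number from compound 1 to compound 3 (0.05 log units; within the scatter). Compound 3 is therefore estimated at 200 nM in this assay, with a range from 70 nM to 600 nM.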

Compound 3, half-maximal inhibitory concentration: 1150 nM
For compound 3 the middle estimate is 5.8-fold (0.76 log units) below the measured one; measured number above the stated range.
By their numbers in this assay, from the lowest: compound 1; then compounds 3 and 2 (each within the scatter of the next).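

In this assay the amine-bearing tail proves to be a part of the molecule that the number responds to: with the core and the 2-methylphenyl group left untouched, exchanging 4-methylpiperazin-1-yl for pyrrolidin-1-yl gives (a 6.4-fold higher number from compound 1 to compound 3 (0.81 log units; beyond the scatter)). Among the compounds shown here, until now only the aryl group had been varied, so this is the first sign that the end of the chain counts too, and compound 1 now stands lowest, with the one-place changes at both sites giving higher numbers beyond the scatter. The exchange alters the ring size and the number of ring nitrogens together, and no measurement here separates these two differences or explains the step.

Still open, from the compounds shown here alone, is whether a piperidin-1-yl or morpholin-4-yl ring on the same propyl chain, or a 2-(4-methylpiperazin-1-yl)ethyl tail, would keep the number close to that of compound 1. Also open, going by these compounds, is whether pyrrolidin-1-yl would have a similar effect alongside the 4-fluorophenyl group of compound 2, since the tail has so far been changed only with the 2-methylphenyl group in place.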